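Cytotoxicity limits and a benzylcarbamoyl exchange

A few compounds are considered here, and "the series" means these few. Any claim that something is new, unique, unknown or untested is made for them only; others in the source may bear on it.

Values in an ADME assay on HeLa cells (Homo sapiens) for cytotoxicity, read by crystal violet staining, with a stated time of 72 h (on this read-out lower numbers stand for higher toxicity in this test and higher numbers for lower toxicity in this test), for the measured compounds
- compound 1 `Cc1cc(-c2noc(C(F)(F)F)n2)cc(C)c1OCCCc1cc(-c2ccccc2)no1` gives > 100000 nM (a limit)
- compound 2 `COc1ccc(-c2cc(CCCOc3c(C)cc(-c4noc(C(F)(F)F)n4)cc3C)on2)cc1OC` gives 41900 nM
- compound 3 `Cc1cc(-c2noc(C(F)(F)F)n2)cc(C)c1OCCCc1cc(-c2ccc(OC(F)(F)F)cc2)no1` gives > 100000 nM (a limit)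

Compound 3 stands at the limit of > 100000 nM in this assay, at which 2 of the 3 values shown sit. Compound 4 `Cc1cc(-c2noc(C(F)(F)F)n2)cc(C)c1OCCCc1cc(C(=O)NCc2ccccc2)no1` carries benzylcarbamoyl in place of 4-(trifluoromethoxy)phenyl on an aromatic carbon. Among the compounds with values here, three measured steps touch this place. The first is an at least 2.3-fold lower number from compound 1 to compound 2 (0.37 log units; beyond the scatter). The second is an at least 2.3-fold higher number from compound 2 to compound 3 (0.37 log units; beyond the scatter). The third is a step that the two limits leave unreadable from compound 1 to compound 3. Only compound 2 gives a number, 41900 nM, so for compound 4 a modest drop, or none beyond the scatter, is expected. The estimated change is an at least 1.4-fold lower number from compound 3 to compound 4 (0.15 log units; that floor lies within the scatter). Compound 4 is expected at 70000 nM, with an estimated range from 30000 nM to 100000 nM.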

Compound 4, half-maximal cytotoxic concentration: > 100000 nM
Compound 4: only a limit was reported; the forecaster's own chance of this, stated with the estimate: 55%; at least 1.4-fold (0.15 log units) between middle value and limit.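

In this assay compound 4 gives > 100000 nM, which is a limit, so a benzylcarbamoyl group, with its carbonyl and amide hydrogen, also leaves this position without a measurable number. Set against 3,4-dimethoxyphenyl, the exchange gives an at least 2.3-fold higher number from compound 2 to compound 4 (0.37 log units; beyond the scatter), and compound 2 remains the exception among the compounds shown: the limit of > 100000 nM in this assay, at which 3 of the 4 values shown sit. The steps from compound 1 and compound 3 to compound 4 cannot be read, since both ends are limits.

As far as these compounds go, how far compound 4 lies beyond the limit stays unknown. Also open, from the compounds shown here alone, is whether an amine or a carboxylic acid at this position would give a number.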